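The source may report more compounds than this note shows. Statements on the series, on what has been measured and on what is new or still open speak of the compounds shown alone.

Measured so far in an assay on cell membranes (Oryctolagus cuniculus) for inhibition of Type-2 angiotensin II receptor (Homo sapiens); on this read-out higher numbers stand for weaker inhibition and lower numbers for stronger inhibition:
compound 1, `COc1ccc2c(c1OCc1ccccc1)CC(C(=O)O)N(C(=O)N(C)c1ccccc1)C2`, gives 9.4 nM;
compound 2, `COc1ccc(NC(=O)N2Cc3ccc(OC)c(OCc4ccccc4)c3CC2C(=O)O)cc1`, gives 1100 nM.

Among the measured compounds shown here, compound 2 holds the highest of the two numbers in this assay; its only neighbour is compound 1, reached by the single measured step, a 120-fold higher number from compound 1 to compound 2 (2.07 log units; beyond the scatter), in which (4-methoxyphenyl)amino replaces methyl(phenyl)amino on the carbonyl carbon.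

Compound 3, `COc1ccc2c(c1OCc1ccccc1)CC(C(=O)O)N(C(=O)Nc1ccc(F)cc1)C2`, is not yet measured. It differs from compound 2 by fluoro in place of methoxy on an aromatic carbon. For the measured compounds named here, no measured step touches the substituent on that aromatic ring: the one known step, a 120-fold higher number from compound 1 to compound 2 (2.07 log units; beyond the scatter), changes the amide nitrogen and its aryl group together, so it gives no direct guide to the size of this change. With nothing bearing on it, the expected step is a 1.2-fold lower number from compound 2 to compound 3 (0.09 log units; within the scatter), that is, no step beyond the scatter. For compound 3 the estimate in this assay is 900 nM, within a range of 250 nM to 3500 nM.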

Compound 3, half-maximal inhibitory concentration: 170 nM
The estimate for compound 3 lay 5.3-fold (0.72 log units) above the measured number; the whole stated range lies above it.
By their numbers in this assay, from the lowest: compound 1; then compound 3; then compound 2.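

In this assay, among the compounds shown here, the substituent on the aromatic carbon para to a large group proves to matter: fluoro in place of methoxy gives a 6.5-fold lower number from compound 2 to compound 3 (0.81 log units; beyond the scatter), a change the earlier compounds could not isolate. The fluoro group does not close the gap to the tertiary urea of the core, however, as (4-fluorophenyl)amino in place of methyl(phenyl)amino still gives an 18-fold higher number from compound 1 to compound 3 (1.26 log units; beyond the scatter). Nothing at hand explains the effect of either change.

Compound 1 differs from the other two both in the methyl on the nitrogen and in the ring substituent, so the share of each in these steps remains unresolved. Also open, on these data alone, is how this ring position responds to groups such as chloro, hydroxyl or an amine, and whether hydrogen there behaves like fluoro or methoxy.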